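The source may hold more compounds than are shown below. What is called first, only, known or untested is meant among the compounds shown, and "the series" means these compounds.

Compound 1 `O=C(O)c1cc(-c2ccccc2)ccc1O` is the reference point here. In a functional assay on the whole organism with Rattus norvegicus as the target (a higher number here means that more compound is needed for the effect, a lower number that less compound is needed), compound 1 gives 54 mg/kg. Compound 2 `O=C(O)c1cc(-c2ccc(I)cc2)ccc1O` gives 120 mg/kg, so compound 1 holds the lower of the two numbers, meaning that less of it is needed for the effect.

Compound 3 `O=C(O)c1cc(-c2ccccc2)cc(F)c1O` has not yet been measured. It keeps the core of compound 1 and makes a single change: fluoro in place of hydrogen on an aromatic carbon. In words, this is fluoro in place of hydrogen on an aromatic carbon, ortho to a hydroxy group.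

Among the measured compounds shown here, only one measured step offers any guidance: a 2.2-fold higher number from compound 1 to compound 2 (0.35 log units; beyond the scatter). That step is modest, and it places iodo, a different group, at a different position in the molecule. For the measured compounds named here, it is also the only example, so it gives weak support for a direction with fluoro. A small step or none beyond the scatter is therefore expected in this assay. The estimated step is a 1.1-fold higher number from compound 1 to compound 3 (0.05 log units; within the scatter), with a slightly higher number as a cautious lean only. For compound 3, the expected value is 60 mg/kg, with an estimated range from 25 mg/kg to 140 mg/kg.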

Compound 3, dose for half-maximal effect: 110 mg/kg
The estimate for compound 3 lay 1.8-fold (0.26 log units) below the measured number; the range from low to high includes it.
By their numbers in this assay, from the lowest: compound 1; then compounds 3 and 2 (each within the scatter of the next).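

In this assay, the exchange of hydrogen for fluoro, ortho to a hydroxy group, gives a 2.0-fold higher number from compound 1 to compound 3 (0.31 log units; beyond the scatter), so this position responds to a change that adds just one fluorine atom. The earlier comparison covered only iodo, at a different place in the molecule, with a 2.2-fold higher number from compound 1 to compound 2 (0.35 log units; beyond the scatter); now both single changes to compound 1 go the same way, and more compound is needed for the effect after each. Nothing measured here gives a reason for the step to compound 3.

Going by these compounds, it remains open whether the higher number belongs to fluoro itself, to any group placed at this position, or to any addition to the core of compound 1. A chlorine atom or an amine at this same position, together with fluoro at another place on the shared core, would help separate these readings and show whether any change to compound 1 can lower the number.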